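Aryl to tert-butyl swap on the triazole carbon

The source may hold more compounds than are shown below. What is called first, only, known or untested is meant among the compounds shown, and "the series" means these compounds.

Compound 1 `Clc1ccccc1-c1nnc2nnc(N3CCCC3)nn12` gives 2660 nM in a functional assay on HL-60 cells (Homo sapiens) for cytotoxicity, read by MTT assay, with a stated time of 72 h; a lower number here means a stronger inhibitor, a higher number a weaker inhibitor. Among the three measured compounds it holds the second highest number: compound 2 `Fc1ccc(-c2nnc3nnc(N4CCCC4)n3n2)cc1` gives 4560 nM in this assay, a value within the scatter of compound 1, while compound 3 `O=[N+]([O-])c1ccc(-c2nnc3nnc(N4CCCCC4)n3n2)cc1` gives 610 nM, a lower number beyond the scatter. Compound 4 `CC(C)(C)c1nnc2nnc(N3CCCC3)nn12` keeps the shared core and the pyrrolidine but differs from compound 1 in one place: tert-butyl in place of 2-chlorophenyl on an aromatic carbon. Among the compounds with values here, no measured pair shows this kind of exchange, so the size of its step is unknown. The estimate for compound 4 rests on compound 1 alone; it is expected at 5000 nM, range 1500 nM to 16000 nM. The expected step of a 1.9-fold higher number from compound 1 to compound 4 (0.27 log units; within the scatter) is toward a higher number, small enough that it may fall within the scatter.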

Compound 4, half-maximal inhibitory concentration: > 100000 nM
Compound 4 ended at the assay's limit (the forecaster's own chance of this, stated with the estimate: 10%); middle value at least 20-fold (1.30 log units) from the limit.
By their numbers in this assay, from the lowest: compound 3; then compounds 1 and 2 (each within the scatter of the next). At a limit, above all of these: compound 4.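

On this aromatic carbon the group matters: tert-butyl in place of 2-chlorophenyl gives an at least 37-fold higher number from compound 1 to compound 4 (1.57 log units; beyond the scatter) in this assay, the first single-place exchange readable in the series. Compound 4 stands at a limit of the assay, so the step gives only a lower bound on the size of the change: the limit of > 100000 nM in this assay, at which 1 of the 4 values shown sits.

The compounds shown do not tell whether an aromatic ring on this carbon is what counts, or whether other non-aromatic groups behave like tert-butyl. Cyclohexyl, unsubstituted phenyl or a longer chain such as n-butyl at this place would separate these readings.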